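Testing the Mirror Image of Compound 2

The source may report more compounds than this note shows. Statements on the series, on what has been measured and on what is new or still open speak of the compounds shown alone.

For the measured compounds named here, in an ADME assay on microsomes from liver (Rattus norvegicus, strain Sprague-Dawley) for pharmacokinetics, read by LC-MS, using NADPH, with a stated time of 45 min, tested at 1 uM (a lower number here means slower removal, a higher number faster removal of the compound), compound 2 (`COc1cc(OCc2ccnc(N)n2)cc2sc(N[C@@H]3CCCC[C@H]3O)nc12`) gives 24 mL/min/kg, the lower of the two numbers so far, while compound 1 (`COc1cc(OCc2ccnc(N)c2Cl)cc2sc(N[C@@H]3CCCC[C@H]3O)nc12`) gives 99 mL/min/kg. Compound 3 (`COc1cc(OCc2ccnc(N)n2)cc2sc(N[C@H]3CCCC[C@@H]3O)nc12`) is the next to be read: the two compounds have the same atoms and bonds and differ only in configuration as drawn: 2 of 2 stereo elements differ (all stereocentres are inverted: mirror images); a stereocentre at a saturated ring carbon is drawn R in compound 2 and S in compound 3; a stereocentre at a saturated ring carbon is drawn R in compound 2 and S in compound 3. Going by the values given here, the only measured step, a 4.1-fold lower number from compound 1 to compound 2 (0.62 log units; beyond the scatter), exchanges 2-amino-3-chloropyridin-4-yl for 2-aminopyrimidin-4-yl and leaves configuration unchanged, so no measured step tests this inversion. With no evidence for a direction, the expected change is no larger than the scatter, an estimated 1.2-fold higher number from compound 2 to compound 3 (0.07 log units; within the scatter). For compound 3 the estimated clearance is 28 mL/min/kg, with an expected range of 12 mL/min/kg to 65 mL/min/kg.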

Compound 3, clearance: 20 mL/min/kg
Beside the measured number, compound 3's estimate is 1.4-fold (0.15 log units) above it; the range from low to high includes it.
By their numbers in this assay, from the lowest: compounds 3 and 2 (each within the scatter of the next); then compound 1.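

In this assay, inverting both stereocentres on the saturated ring gives a 1.2-fold lower number from compound 2 to compound 3 (0.08 log units; within the scatter), the first measured test of configuration at this position. Rat microsomal clearance therefore does not separate these two mirror images, whereas the ring exchange in the earlier step gave a 4.1-fold lower number from compound 1 to compound 2 (0.62 log units; beyond the scatter). The comparison isolates configuration alone: the fact that compounds 2 and 3 differ only in the configuration as drawn.

The compounds shown leave open whether inverting only one of the two stereocentres would give a similar reading. They also leave open how an amine in place of the hydroxyl on the saturated ring would read.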